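Metabolic stability notes: amino-substituted analogues of a shared core

This account rests on a few compounds, and the source may have more. Where it says the series, first, only, none or still open, it means among the compounds named here.

Measured compounds in an ADME assay on microsomes from liver (Homo sapiens) for metabolic stability, read by LC-MS, using NADPH, with stated times of 5 min and 30 min, tested at 1 uM; a lower number here means slower removal, a higher number faster removal of the compound:
compound 1 `O=C1c2ccccc2CN1c1cnc(NCc2c(F)ccc3c2CCO3)n2cnnc12`, 13 mL.min-1.g-1
compound 2 `CN(c1ccccc1)c1cnc(NCc2c(F)ccc3c2CCO3)n2cnnc12`, 55 mL.min-1.g-1
compound 3 `Cn1nccc1-c1cnc(NCc2c(F)ccc3c2CCO3)c2cn[nH]c(=O)c12`, 14 mL.min-1.g-1

For the measured compounds named here, compound 2 gives the highest of the three numbers in this assay; compound 1 and compound 3 both lie well below it, with the step of a 4.2-fold higher number from compound 1 to compound 2 (0.63 log units; beyond the scatter) being the only pairwise change measured at the nitrogen on the aromatic ring. Compound 4 `CN(c1ncco1)c1cnc(NCc2c(F)ccc3c2CCO3)n2cnnc12` differs from compound 2 by 1,3-oxazol-2-yl in place of phenyl on a nitrogen on an aromatic ring. Going by the values given here, no measured step exchanges an aryl group on that nitrogen for a heteroaryl group, so the step from compound 1 to compound 2 is the only one that touches this position, and it only marks the position as one where this assay responds. A modest step in either direction is plausible; the working expectation for compound 4 is a somewhat lower number, a 1.7-fold lower number from compound 2 to compound 4 (0.24 log units; within the scatter). Compound 4 is thus estimated at 32 mL.min-1.g-1, within 13 mL.min-1.g-1 to 75 mL.min-1.g-1.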

Compound 4, intrinsic clearance in microsomes: 11 mL.min-1.g-1
Compound 4: the middle estimate sits 2.9-fold (0.46 log units) above what was measured; the whole stated range lies above it.
By their numbers in this assay, from the lowest: compounds 4, 1 and 3 (each within the scatter of the next); then compound 2.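

In this assay, for the compounds shown here, the group on this nitrogen matters by itself: with the methyl kept, 1,3-oxazol-2-yl in place of phenyl gives a 5.0-fold lower number from compound 2 to compound 4 (0.70 log units; beyond the scatter), a step at this position that the earlier compounds did not isolate. The exchange also brings the series back level with the group in compound 1, with a 1.2-fold lower number from compound 1 to compound 4 (0.07 log units; within the scatter). Nothing available bears on why the number moves. Open, as far as these compounds go, is whether a pyridin-2-yl or thiazol-2-yl group on this nitrogen follows compound 4 or compound 2. Also open, from the compounds shown here alone, is whether the step survives with an ethyl in place of the methyl.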